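Swapping the Amide Ring for a Methylpyridine

The source may hold more compounds than are shown below. What is called first, only, known or untested is meant among the compounds shown, and "the series" means these compounds.

Measured compounds:
Compound 1 `O=C(C1CCCO1)N1CCc2nc(C#Cc3ccccc3)sc2C1` gives 790 nM in an assay on HEK293 cells for positive allosteric modulation of metabotropic glutamate receptor 5 (Homo sapiens), read by FLIPR, with a stated time of 1 h; on this read-out lower numbers stand for an effect already at smaller amounts and higher numbers for an effect only at larger amounts of compound.
Compound 2 `CC1CCCC(C(=O)N2CCc3nc(C#Cc4ccccc4)sc3C2)C1` gives 100 nM in this assay.
Compound 3 `O=C(C1CCCCO1)N1CCc2nc(C#Cc3ccccc3)sc2C1` gives 320 nM in this assay.

All three share the same core and differ only in the ring attached to the carbonyl carbon. Compound 3 stands second highest of the three numbers: compound 1 sits above it by a 2.5-fold lower number from compound 1 to compound 3 (0.39 log units; beyond the scatter), and compound 2 sits below it by a 3.2-fold higher number from compound 2 to compound 3 (0.51 log units; beyond the scatter). The largest measured step, a 7.9-fold lower number from compound 1 to compound 2 (0.90 log units; beyond the scatter), likewise comes from replacing a ring on this carbonyl carbon.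

Compound 4 `Cc1cccc(C(=O)N2CCc3nc(C#Cc4ccccc4)sc3C2)n1` has not been measured. Its change from compound 3 is 6-methylpyridin-2-yl in place of oxan-2-yl on a carbonyl carbon. Among the measured compounds shown here, no measured step moves from a non-aromatic ring to an aromatic one, so the three steps only show that this position tolerates a change of ring with modest shifts, in both directions. The step I therefore expect is a modest one downward, estimated as a 2.1-fold lower number from compound 3 to compound 4 (0.33 log units; beyond the scatter), with wide uncertainty. Compound 4 is estimated at 150 nM, within 40 nM to 600 nM.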

Compound 4, half-maximal effective concentration: 160 nM
Estimate against measurement, compound 4: 1.1-fold (0.03 log units) below; low and high end bracket the measured number.
By their numbers in this assay, from the lowest: compounds 2, 4 and 3 (each within the scatter of the next, the first and the last beyond it); then compound 1.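

An aromatic ring is accepted on this carbonyl carbon, which the three non-aromatic rings could not show: 6-methylpyridin-2-yl in place of oxan-2-yl gives a 2.0-fold lower number from compound 3 to compound 4 (0.30 log units; within the scatter), and in place of 3-methylcyclohexyl it gives a 1.6-fold higher number from compound 2 to compound 4 (0.20 log units; within the scatter), so compound 4 cannot be ranked against either neighbour. Only the oxolan-2-yl ring stands apart from the new group, with a 4.9-fold lower number from compound 1 to compound 4 (0.69 log units; beyond the scatter). No measurement offered here explains why these rings give such numbers.

On these data alone, how a plain phenyl ring or an unsubstituted pyridin-2-yl would compare on this carbonyl carbon remains open, and so does the part played by the methyl of 6-methylpyridin-2-yl. Also open, as far as these compounds go, is what a ring carrying an amine or a carboxylic acid would do here.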